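Phenyl in Place of Imidazolyl: What Compound 4 Might Show

A few compounds are considered here, and "the series" means these few. Any claim that something is new, unique, unknown or untested is made for them only; others in the source may bear on it.

Compound 3 `O=C(O)/C=C/c1ccc(Cn2ccnc2)cc1OCCc1ccc2ccccc2c1` belongs to a small set of three measured compounds that share one core and differ in the ring carried on a saturated chain carbon bound to an aromatic carbon, or in the chain attached to the ring oxygen. In an assay on CHO cells for displacement of a labelled ligand from prostaglandin E2 receptor EP2 subtype (Mus musculus), read by scintillation counting (on this read-out lower numbers stand for stronger inhibition and higher numbers for weaker inhibition), compound 3 gives > 10000 nM, which is a limit of the assay rather than a number. Compound 1 `O=C(O)/C=C/c1ccc(Cn2cccn2)cc1OCCc1ccc2ccccc2c1` carries 1H-pyrazol-1-yl in that place; in this assay compound 1 gives 3300 nM. Compound 2 `O=C(O)/C=C/c1ccc(Cn2ccnc2)cc1OCCCOc1ccccc1` carries the imidazolyl ring together with a phenoxymethyl chain. In this assay compound 2 gives > 10000 nM, again a limit. The step of an at least 3.0-fold higher number from compound 1 to compound 3 (0.48 log units; beyond the scatter) shows that exchanging pyrazolyl for imidazolyl weakened binding. The step that the two limits leave unreadable from compound 2 to compound 3 cannot be read, since both ends sit at the limit (the limit of > 10000 nM in this assay, at which 2 of the 3 values shown sit).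

Compound 4 `O=C(O)/C=C/c1ccc(Cc2ccccc2)cc1OCCc1ccc2ccccc2c1` has not yet been measured. It differs from compound 3 by phenyl in place of 1H-imidazol-1-yl on a saturated chain carbon bound to an aromatic carbon. Within the data shown here, no measured step covers a phenyl ring in this place; the only step touching the same position went from pyrazolyl to imidazolyl and weakened binding. With compound 3 standing at a limit, the step of an at least 2.5-fold lower number from compound 3 to compound 4 (0.39 log units; beyond the scatter) is expected, though its true size cannot be anchored. Compound 4 is therefore estimated at 4000 nM, within a range from 800 nM to 20000 nM.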

Compound 4, inhibition constant: > 10000 nM
Compound 4 was reported as a limit; the forecaster's own chance of this, stated with the estimate: 40%; middle value at least 2.5-fold (0.39 log units) away from the limit.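

At the place on a saturated chain carbon bound to an aromatic carbon, phenyl in place of 1H-pyrazol-1-yl gives an at least 3.0-fold higher number from compound 1 to compound 4 (0.48 log units; beyond the scatter) in this assay, so a second replacement for that ring, this one of carbon only, also weakens binding. Compound 4 gives > 10000 nM, which is a limit and not a number, so the step between it and the imidazolyl compound 3 cannot be read, and neither ring can be ranked above the other. 1H-imidazol-1-yl, with 2 hydrogen-bond acceptors, and phenyl, with 0 hydrogen-bond acceptors, both leave the compound at the same limit, so this count does not separate the two in the assay, and among the compounds sharing the naphthalen-2-yl chain only the pyrazolyl compound 1 gives a number: the limit of > 10000 nM in this assay, at which 3 of the 4 values shown sit.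

Still open, going by these compounds, is how far compound 3 and compound 4 lie beyond their limits, and whether any group at this place, such as a phenyl ring carrying an amine, could bind more strongly than the pyrazolyl ring of compound 1. Also open, on these data alone, is whether a longer chain on the ring oxygen would change the picture for the pyrazolyl ring.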